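This account rests on a few compounds, and the source may have more. Where it says the series, first, only, none or still open, it means among the compounds named here.

Compound 2 `CC(=O)c1ccc(OCCSC(=S)N[C@H]2CCOC2=O)cc1` carries an acetyl group on its aromatic ring. In a functional assay on MGC-803 cells (Homo sapiens) for antiproliferative activity, read by MTT assay, with a stated time of 72 h (on this read-out higher numbers stand for weaker inhibition and lower numbers for stronger inhibition), compound 2 gives only a limit, > 64000 nM. Compound 1 `O=C1OCC[C@@H]1NC(=S)SCCOc1ccc([N+](=O)[O-])cc1` differs by a nitro group in place of that acetyl. In this assay compound 1 also gives only a limit, > 100000 nM. The step that the two limits leave unreadable from compound 1 to compound 2 thus cannot be read, as both values sit at limits, the limit of > 100000 nM in this assay, at which 1 of the 2 values shown sits, and (the limit of > 64000 nM in this assay, at which 1 of the 2 values shown sits). Compound 3 `O=C1OCC[C@@H]1NC(=S)SCCOc1ccc(Cl)cc1` brings the change (chloro in place of acetyl on an aromatic carbon), chloro in place of acetyl on an aromatic carbon. Within the data shown here, no measured step bears on it, so no change beyond the scatter is expected, an estimated step that the limit leaves unreadable from compound 2 to compound 3. Compound 3 is expected near 80000 nM, between 25000 nM and 250000 nM.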

Compound 3, half-maximal inhibitory concentration: 51100 nM
Estimate against measurement, compound 3: 1.6-fold (0.19 log units) above, and the stated range covers the measured number.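

Among these compounds, with chloro on this aromatic carbon, compound 3 is the first here to give a real number rather than a limit in this assay, and the steps to it are an at least 1.2-fold lower number from compound 2 to compound 3 (0.09 log units; that floor lies within the scatter) and an at least 1.9-fold lower number from compound 1 to compound 3 (0.29 log units; that floor lies within the scatter). Compound 1 gives only a limit, so its step is a floor, because its true value is unknown: the limit of > 100000 nM in this assay, at which 1 of the 3 values shown sits. Compound 2 also gives only a limit, so its step is a floor for the same reason: the limit of > 64000 nM in this assay, at which 1 of the 3 values shown sits.

On these data alone, whether the true differences exceed the scatter stays open. So does how an amine or a carboxylic acid at this position would read in this assay.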